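The source may report more compounds than this note shows. Statements on the series, on what has been measured and on what is new or still open speak of the compounds shown alone.

Measured so far in an ADME assay on microsomes from liver (Homo sapiens) for metabolic stability, with a stated time of 30 min; a higher number here means that more of the compound is left, a lower number that less of the compound is left:

Compound 1 `CC(C)[C@@H](CO)n1cc(C(=O)O)c(=O)c2nc(Cc3cccc(Cl)c3F)ccc21`: "not determined" (no result reported)
Compound 2 `CCOc1nc2c(cc1Cc1cccc(Cl)c1F)c(=O)c(C(=O)O)cn2[C@H](CO)C(C)(C)C`: 84%
Compound 3 `COc1nc2c(cc1Nc1ccc(Cl)c(F)c1)c(=O)c(C(=O)O)cn2[C@H](CO)C(C)C`: "not determined" (no result reported)

For the measured compounds named here, only one of these three compounds has a number in this assay. Compound 3 stands at "not determined" (no result reported) and so has no place on the scale, and compound 1 shares that position at "not determined" (no result reported). Going by the values given here, the sole numerical reading is that of compound 2 at 84%, which shows a large share of the compound left after incubation.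

The next compound to be tested is compound 4 `COc1nc2c(cc1NCc1ccc(F)cc1)c(=O)c(C(=O)O)cn2[C@H](CO)C(C)C`. It carries 4-fluorobenzyl in place of 4-chloro-3-fluorophenyl on a nitrogen on an aromatic ring. The rest of the structure stays as it is in compound 3.

Among the compounds with values here, no measured step between closely related compounds is available, so the size of this change cannot be read from the data. With no starting number for compound 3, the expectation is necessarily loose: a moderate step towards less compound left, possibly no larger than the usual scatter. Within the data shown here, the only anchor is compound 2 at 84%, and the expected value is set somewhat lower than that reading, with a wide margin.

Compound 4 is estimated at 70%, with an expected range of 40% to 92%.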

Compound 4, percent of the compound remaining: 87%
Compound 4: middle estimate off by 17 percentage points, on the low side; the range from low to high includes it.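

In this assay, for the compounds shown here, compound 4 reads 87% while compound 3 stands at "not determined" (no result reported) and so no step between compound 3 and compound 4 can be read. The compounds shown leave open how far the change from 4-chloro-3-fluorophenyl to 4-fluorobenzyl shifts the share of compound left. Nothing available bears on the reading of compound 4.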